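From fluoro to isobutylcarbamoyl on a weak growth inhibitor

The source may report more compounds than this note shows. Statements on the series, on what has been measured and on what is new or still open speak of the compounds shown alone.

In a functional assay on NCI-H1975 cells (Homo sapiens) for antiproliferative activity, read by CCK-8 assay, with a stated time of 72 h (on this read-out lower numbers stand for stronger inhibition of growth and higher numbers for weaker inhibition of growth), compound 1 (`CCC1C(=O)N(C)c2cnc(Nc3ccc(S(=O)(=O)NC)cc3)nc2N1c1ccn(C)n1`) gives 18800 nM. Compound 2 (`CC[C@@H]1C(=O)N(C)c2cnc(-n3ccc4cc(F)ccc43)nc2N1C1CCCC1`) gives 46500 nM, the higher of the two numbers and beyond the scatter from compound 1. Compound 3 (`CC[C@@H]1C(=O)N(C)c2cnc(-n3ccc4cc(C(=O)NCC(C)C)ccc43)nc2N1C1CCCC1`) has isobutylcarbamoyl in place of fluoro on an aromatic carbon. Within the data shown here, no measured pair shows this kind of change, so the expectation remains loose. A moderate move towards stronger inhibition of growth is expected, with an estimated step of a 3.1-fold lower number from compound 2 to compound 3 (0.49 log units; beyond the scatter). Compound 3 is estimated at 15000 nM, with an expected range of 3000 nM to 60000 nM.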

Compound 3, concentration for 50% growth inhibition: "not active" (no number reported)
The entry for compound 3 holds no number; there is nothing to compare the estimate with.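

In this assay, among these compounds, compound 3 is reported as not active, without a number, so no step from compound 2 to compound 3 can be read. Nothing shown here accounts for this result. The compounds shown leave open how far isobutylcarbamoyl in place of fluoro shifts growth inhibition.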